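The compounds below may be only part of what the source reports. "The series", "measured", "known", "first", "only" and "open" are said of these compounds alone.

Measured compounds:
compound 1, `CC(C)(Oc1ccccc1[N+](=O)[O-])C1OCC(C/C=C\CCC(=O)O)C(c2cccnc2)O1` — < 10 nM
compound 2, `CC(C)(Oc1ccc(F)cc1[N+](=O)[O-])C1OCC(C/C=C\CCC(=O)O)C(c2cccnc2)O1` — 20 nM
compound 3, `CC(C)(Cc1ccccc1)C1OCC(C/C=C\CCC(=O)O)C(c2cccnc2)O1` — 12 nM

In an assay for inhibition of Thromboxane-A synthase (Homo sapiens), using microsomes (on this read-out lower numbers stand for stronger inhibition and higher numbers for weaker inhibition), compound 1 reaches only a limit of the assay, < 10 nM, so its true number is not known (the limit of < 10 nM in this assay, at which 1 of the 3 values shown sits). Compound 2 gives 20 nM in this assay. Compound 3 gives 12 nM in this assay. The change fluoro in place of hydrogen on an aromatic carbon produced an at least 2.0-fold higher number from compound 1 to compound 2 (0.30 log units; that floor lies within the scatter). The two cores differ as follows: benzyl in place of 2-nitrophenoxy on a saturated chain carbon bound to two saturated chain carbons and a saturated ring carbon, and this gave an at least 1.2-fold higher number from compound 1 to compound 3 (0.07 log units; that floor lies within the scatter). Between compound 2 and compound 3 there is a 1.7-fold lower number from compound 2 to compound 3 (0.22 log units; within the scatter).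

Compound 4, `CC(C)(Cc1ccc(F)cc1)C1OCC(C/C=C\CCC(=O)O)C(c2cccnc2)O1`, is not yet measured. It differs from compound 3 by fluoro in place of hydrogen on an aromatic carbon. Among the compounds with values here, this is the same kind of change as the one from compound 1 to compound 2, but there the fluoro entered meta to a nitro group, whereas here no nitro group is present. For compound 4 the expected step is a 1.7-fold higher number from compound 3 to compound 4 (0.22 log units; within the scatter), resting on the earlier floor of an at least 2.0-fold higher number from compound 1 to compound 2 (0.30 log units; that floor lies within the scatter), which sits within the scatter. Compound 4 is therefore estimated at 20 nM, with an expected range from 8 nM to 50 nM.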

Compound 4, half-maximal inhibitory concentration: 45 nM
Estimate against measurement, compound 4: 2.3-fold (0.35 log units) below; the measured number falls inside the stated range.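

In this assay, the change from benzyl to 4-fluorobenzyl gave a 3.8-fold higher number from compound 3 to compound 4 (0.57 log units; beyond the scatter), and the larger replacements of the two 2-nitrophenoxy-type groups by 4-fluorobenzyl gave a 2.3-fold higher number from compound 2 to compound 4 (0.35 log units; beyond the scatter) and an at least 4.5-fold higher number from compound 1 to compound 4 (0.65 log units; beyond the scatter). Fluoro in place of hydrogen raises the number on both cores shown, but this is only two cases, and the earlier step is a floor, so the size of the step on one core cannot be said to match or differ from its size on the other: the same change on two cores in this assay, an at least 2.0-fold higher number (0.30 log units; that floor lies within the scatter) from compound 1 to compound 2 and a 3.8-fold higher number (0.57 log units; beyond the scatter) from compound 3 to compound 4; the limit leaves it open whether they differ. On these data alone, the comparison stays open at the compound 1 end, where the assay gives only a limit: the limit of < 10 nM in this assay, at which 1 of the 4 values shown sits.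

The compounds shown leave open whether chloro or methoxy in place of the fluoro would give a step of similar size on either core. They also leave open how fluoro would act on another carbon of the same ring, or on the core with an amide in place of the carboxylic acid.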